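The source may report more compounds than this note shows. Statements on the series, on what has been measured and on what is new or still open speak of the compounds shown alone.

Compound 1 `CN1CCN(CCNCc2cn(-c3ccc(F)cc3F)nc2-c2ccccc2)CC1` was tested in an ADME assay on Huh-7 cells (Homo sapiens) for cytotoxicity (on this read-out lower numbers stand for higher toxicity in this test and higher numbers for lower toxicity in this test), and the result for compound 1 is a limit of the assay rather than a number, > 20000 nM. That places compound 1 at the limit of > 20000 nM in this assay, at which 1 of the 2 values shown sits. Going by the values given here, a second compound, compound 2 `Cc1ccccc1-c1nn(-c2ccc(OC(F)(F)F)cc2)cc1CNCCN1CCN(C)CC1`, built on the same core but with different groups around it, gives 17000 nM in this assay, the only value here that is an actual number. The unmeasured compound 3 `CN1CCN(CCNCc2cn(-c3ccc(F)cc3F)nc2-c2cccc(N(C)C)c2)CC1` is compound 1 with a single change: dimethylamino in place of hydrogen on an aromatic carbon. Among the compounds with values here, no two measured compounds differ in just one place, so the size of this step cannot be read from a neighbouring pair. With compound 1 already at the limit of this assay, the expected step is no larger than the usual scatter, a number no higher from compound 1 to compound 3 (the limit leaves the size open), in either direction. Compound 3 is therefore estimated to give about 20000 nM, within a range from 8000 nM to 50000 nM.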

Compound 3, half-maximal cytotoxic concentration: > 20000 nM
Compound 3: no number, only a limit; the forecaster's own chance of this, stated with the estimate: 55%; the middle value lies on the limit itself.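

Going by these compounds alone, compound 1 and compound 3 both give only a limit in this assay, not a number, so no step between them can be read: the limit of > 20000 nM in this assay, at which 2 of the 3 values shown sit.

The compounds shown leave open whether dimethylamino in place of hydrogen on an aromatic carbon changes this read-out at all, and by how much.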